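The source may report more compounds than this note shows. Statements on the series, on what has been measured and on what is new or still open speak of the compounds shown alone.

Of the compounds shown here, three sharing one core have been measured in an assay on CHO cells for displacement of a labelled ligand from adenosine receptor A3 (Homo sapiens), read by scintillation counting, with a stated time of 3 h; on this read-out lower numbers stand for stronger inhibition and higher numbers for weaker inhibition. Compound 1 `CCn1c(-c2ccccc2)nc2c(NC3CCCCC3)ncnc21` gives 707 nM. Compound 2 `Cn1c(-c2ccc(C(=O)O)cc2)nc2c(NC3CCCC3)ncnc21` gives 25700 nM, and compound 3 `COc1ccc(-c2nc3c(NC4CCCC4)ncnc3n2C)cc1` gives 1850 nM. On these numbers compound 3 stands second highest of the three: compound 1 lies below it, beyond the scatter, and compound 2 lies far above it. For the measured compounds named here, the one single-point step measured so far, a 14-fold lower number from compound 2 to compound 3 (1.14 log units; beyond the scatter), shows that the group on the aromatic carbon of the five-membered ring, between two ring nitrogen atoms, can move the number by a large amount. Compound 4 `Cc1cccc(-c2nc3c(NC4CCCC4)ncnc3n2C)c1` is the next step, with the change (3-methylphenyl in place of 4-methoxyphenyl on an aromatic carbon). Going by the values given here, no measured step swaps a methoxy for a methyl or shifts a substituent around the phenyl, so the carboxy-to-methoxy step is only a loose hint that this position matters. A step of modest size, toward a lower number, is expected in this assay, a 1.5-fold lower number from compound 3 to compound 4 (0.19 log units; within the scatter). Compound 4 is therefore estimated at 1200 nM, with a range from 400 nM to 4000 nM.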

Compound 4, inhibition constant: 510 nM
Compound 4: the middle estimate sits 2.4-fold (0.37 log units) above what was measured, within the range that was stated.
By their numbers in this assay, from the lowest: compounds 4 and 1 (each within the scatter of the next); then compound 3; then compound 2.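

In this assay, putting 3-methylphenyl in place of 4-methoxyphenyl gives a 3.6-fold lower number from compound 3 to compound 4 (0.56 log units; beyond the scatter). The number at this position therefore moves beyond the scatter even between two phenyl groups that carry no carboxy group, although this step is modest beside the large step from carboxy to methoxy. The swap is not a single edit, however: the substituent on the phenyl ring changes from methoxy to methyl, and its place on that ring changes too, so the step belongs to the whole group.

On these data alone, whether the lower number follows the methyl group or its place on the ring stays open, as does what an amine or a chlorine on the phenyl ring would do on the same core. No supporting data offer a reason for this step.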